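This account rests on a few compounds, and the source may have more. Where it says the series, first, only, none or still open, it means among the compounds named here.

Working notes on the series. Compound 1 `COc1cccc(/C=N/NC(=O)CSc2nnnn2-c2cccc3ccccc23)c1OC`, compound 2 `COc1cc(/C=N/NC(=O)CSc2nnnn2-c2cccc3ccccc23)ccc1O` and compound 3 `CN(C)c1ccc(/C=N/NC(=O)CSc2nnnn2-c2cccc3ccccc23)cc1` share one core and differ only in the aryl group on the carbon with a double bond to nitrogen. In an ADME assay on MT4 cells (Homo sapiens) for cytotoxicity, read by MTT assay (a higher number here means that more compound is tolerated, a lower number that less compound is tolerated), compound 1 gives 192000 nM. For compound 2 this assay reports only a limit, > 287000 nM. For compound 3 this assay likewise reports only a limit, > 289000 nM. Compound 3 therefore stands at a limit of the assay rather than at a number. The measured steps that lead to it are an at least 1.5-fold higher number from compound 1 to compound 3 (0.17 log units; that floor lies within the scatter) and a step that the two limits leave unreadable from compound 2 to compound 3, the latter because both ends sit at limits (the limit of > 287000 nM in this assay, at which 1 of the 3 values shown sits, (the limit of > 289000 nM in this assay, at which 1 of the 3 values shown sits)); for completeness, an at least 1.4-fold higher number from compound 1 to compound 2 (0.17 log units; that floor lies within the scatter). Compound 4 `O=C(CSc1nnnn1-c1cccc2ccccc12)N/N=C/c1ccccc1` arises from compound 3 by hydrogen in place of dimethylamino on an aromatic carbon. None of the three measured steps removes a ring substituent outright, and none reads as beyond the scatter, so no step beyond the scatter is expected here, an at least 1.1-fold lower number from compound 3 to compound 4 (0.06 log units; that floor lies within the scatter). Compound 4 is estimated at 250000 nM, in the range 120000 nM to 300000 nM, with a fair chance that this assay again reports only a limit.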

Compound 4, half-maximal cytotoxic concentration: 216000 nM
For compound 4 the middle estimate is 1.2-fold (0.06 log units) above the measured one; the range from low to high includes it.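

Among the compounds shown here, removing the ring substituent outright gives the first measured value for plain phenyl in this assay, and the floors for the two steps that begin at limits stay within the scatter: an at least 1.3-fold lower number from compound 3 to compound 4 (0.12 log units; that floor lies within the scatter) and an at least 1.3-fold lower number from compound 2 to compound 4 (0.12 log units; that floor lies within the scatter). For the compounds shown here, the one step here with a number at both ends, a 1.1-fold higher number from compound 1 to compound 4 (0.05 log units; within the scatter), does not separate phenyl from 2,3-dimethoxyphenyl. Compound 3 stands at a limit, so the step from dimethylamino to hydrogen gives only a floor: the limit of > 289000 nM in this assay, at which 1 of the 4 values shown sits.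

Going by these compounds, the true size of the steps that begin at limits remains open, and so does whether any substituent at this place moves the reading in this assay beyond the scatter. On these data alone, how a carboxylic acid or a longer amine chain on this aromatic carbon would read also remains open.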